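A few compounds are considered here, and "the series" means these few. Any claim that something is new, unique, unknown or untested is made for them only; others in the source may bear on it.

Measured compounds in a functional assay on MCF7 cells (Homo sapiens) for antiproliferative activity, read by MTT assay, with a stated time of 72 h; on this read-out lower numbers stand for stronger inhibition and higher numbers for weaker inhibition:

compound 1 `COc1cc(-n2cnc3ccc(-c4ccc(Cl)cc4)cc32)cc(OC)c1OC` gives 1320 nM
compound 2 `COc1cc(-n2cnc3ccc(-c4cc(F)ccc4F)cc32)cc(OC)c1OC` gives 6420 nM
compound 3 `COc1cc(-n2cnc3ccc(-c4cccc(C)c4C)cc32)cc(OC)c1OC` gives 2150 nM

Compound 3 holds the second highest of the three numbers. Its nearest neighbour is compound 1, and the step of a 1.6-fold higher number from compound 1 to compound 3 (0.21 log units; within the scatter) sits within the scatter, so the two cannot be ordered. Its furthest neighbour is compound 2, with a 3.0-fold lower number from compound 2 to compound 3 (0.48 log units; beyond the scatter), a modest but real gap. The full range of the series under this assay is thus set by a 4.9-fold higher number from compound 1 to compound 2 (0.69 log units; beyond the scatter), and all three compounds differ only in the aryl group on the shared core.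

Compound 4 `COc1ccc(-c2ccc3ncn(-c4cc(OC)c(OC)c(OC)c4)c3c2)cc1F` continues this aryl variation: 3-fluoro-4-methoxyphenyl in place of 2,3-dimethylphenyl on an aromatic carbon.

For the measured compounds named here, no measured pair has a 3-fluoro-4-methoxyphenyl group, so no direct step bears on it. The steps that do bear are those changing the aryl group itself: the 4-chlorophenyl to 2,3-dimethylphenyl change stayed within the scatter, while the 2,5-difluorophenyl analogue gave the weakest number. Three aryl groups span only a modest range, so the expected step in this assay from compound 3 to compound 4 is small and uncertain in direction.

Compound 4 is estimated at 2000 nM, range 800 nM to 6000 nM, meaning an expected step of a 1.1-fold lower number from compound 3 to compound 4 (0.03 log units; within the scatter).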

Compound 4, half-maximal inhibitory concentration: 520 nM
Compound 4: the middle estimate sits 3.8-fold (0.59 log units) above what was measured; the measured number lies below the stated range.
By their numbers in this assay, from the lowest: compound 4; then compounds 1 and 3 (each within the scatter of the next); then compound 2.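

The aryl group on this aromatic carbon can move the number beyond the scatter in the favourable direction: in this assay, 3-fluoro-4-methoxyphenyl gives a 4.1-fold lower number from compound 3 to compound 4 (0.62 log units; beyond the scatter) and a 2.5-fold lower number from compound 1 to compound 4 (0.40 log units; beyond the scatter), so compound 4 has the lowest number of the series, clear of both groups that had been level within the scatter. Fluorine on the aryl group does not by itself account for this, since the other fluorine-bearing compound marks the far end of the range, with a 12-fold lower number from compound 2 to compound 4 (1.09 log units; beyond the scatter), the only large step so far, and the change at this position now spans more than the earlier compounds showed. 3-Fluoro-4-methoxyphenyl is also the only aryl group here with a hydrogen-bond acceptor, but that is a single compound and a count rather than an explanation, and nothing available speaks to the origin of the gain.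

The compounds shown leave open whether the methoxy or the fluorine carries the step, which 4-methoxyphenyl and 3-fluorophenyl groups at this carbon would separate. They also leave open how an aryl group bearing an amine or a carboxylic acid would read in this assay.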